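Shrinking the urea substituent: from tert-butyl to methyl

The compounds below may be only part of what the source reports. "The series", "measured", "known", "first", "only" and "open" are said of these compounds alone.

Compound 1 `CC(C)CNC(=O)NCCCOc1cccc(CN2CCCCC2)c1`: 170 nM
Compound 2 `CC(C)(C)NC(=O)NCCCOc1cccc(CN2CCCCC2)c1`: 2090 nM

In an assay on isolated protein for inhibition of histamine H2 receptor (Cavia porcellus) (a higher number here means weaker binding, a lower number tighter binding), compound 2 gives 2090 nM, the higher of the two numbers measured; its nearest neighbour is compound 1 at 170 nM. Among the compounds with values here, the one step measured so far, a 12-fold higher number from compound 1 to compound 2 (1.09 log units; beyond the scatter), is large. Compound 3 `CNC(=O)NCCCOc1cccc(CN2CCCCC2)c1` carries the change (methyl in place of tert-butyl on an amide-type nitrogen). Within the data shown here, since moving from isobutyl to the bulkier tert-butyl weakened binding, the step back to a smaller group is expected to lower the number, roughly a 10-fold lower number from compound 2 to compound 3 (1.02 log units; beyond the scatter), though only one step supports this. Compound 3 is therefore estimated at 200 nM, within 60 nM to 700 nM.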

Compound 3, dissociation constant: 155 nM
Estimate against measurement, compound 3: 1.3-fold (0.11 log units) above; the range from low to high includes it.
By their numbers in this assay, from the lowest: compounds 3 and 1 (each within the scatter of the next); then compound 2.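

In this assay, within the data shown here, the amide-type nitrogen responds strongly to the swap of tert-butyl for methyl (a 13-fold lower number from compound 2 to compound 3 (1.13 log units; beyond the scatter)), the largest step so far seen in the opposite direction to the earlier one. Methyl and isobutyl, however, cannot be told apart (a 1.1-fold lower number from compound 1 to compound 3 (0.04 log units; within the scatter)), so among these three groups only tert-butyl stands out, and the number does not follow the heavy-atom count of the substituent. Nothing available explains why tert-butyl differs.

Going by these compounds, it remains open whether isopropyl, cyclohexyl or a longer chain such as n-hexyl would behave like isobutyl or like tert-butyl. On these data alone, whether the bare urea, with hydrogen in place of methyl, holds the same level is also open.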